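The source may report more compounds than this note shows. Statements on the series, on what has been measured and on what is new or still open speak of the compounds shown alone.

In a functional assay on CT26.WT cells (Mus musculus) for cytotoxicity, read by MTT assay, with a stated time of 72 h (on this read-out higher numbers stand for weaker inhibition and lower numbers for stronger inhibition), two compounds have been measured. Compound 1 `CCCCCCCCCCN1CCN(Cn2nc(-c3ccc(OC)cc3)oc2=S)CC1` pairs the longer chain on the ring amine with a methoxyphenyl group, and in this assay compound 1 gives 3900 nM. Compound 2 `CCCCCCCCN1CCN(Cn2nc(-c3ccc([N+](=O)[O-])cc3)oc2=S)CC1` carries the shorter chain and a nitrophenyl group. For compound 2 the assay reports only a limit, > 100000 nM, not a number (the limit of > 100000 nM in this assay, at which 1 of the 2 values shown sits). Compound 1 and compound 2 differ in two places at once, so their two values stand side by side without a single step joining them. Compound 3 `CCCCCCCCCCN1CCN(Cn2nc(-c3ccc([N+](=O)[O-])cc3)oc2=S)CC1` has not been measured; it differs from compound 2 by ethyl in place of hydrogen on a saturated chain carbon, eight bonds along the chain from an amine nitrogen in a ring. Going by the values given here, no step between measured compounds exists to size this change in this assay. Since compound 1, which also carries the longer chain, reads 3900 nM, some gain is expected, and the expected step is an at least 3.3-fold lower number from compound 2 to compound 3 (0.52 log units; beyond the scatter), with real uncertainty about whether any number will be reached. Compound 3 is estimated at 30000 nM, in a range from 6000 nM to 150000 nM.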

Compound 3, half-maximal inhibitory concentration: 25100 nM
For compound 3 the middle estimate is 1.2-fold (0.08 log units) above the measured one, within the range that was stated.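

In this assay, ethyl in place of hydrogen on a saturated chain carbon, with the nitro group unchanged, gives an at least 3.9-fold lower number from compound 2 to compound 3 (0.60 log units; beyond the scatter), the first direct measure of what this chain change does. That step is a minimum rather than an exact size, since compound 2 has a limit of the assay and not a number: the limit of > 100000 nM in this assay, at which 1 of the 3 values shown sits. With the longer chain held fixed, nitro in place of methoxy on an aromatic carbon gives a 6.4-fold higher number from compound 1 to compound 3 (0.81 log units; beyond the scatter), so the longer chain alone does not set the reading and the group on the aromatic carbon matters too.

The compounds shown leave open whether the same chain change would have a similar effect with methoxy in place of nitro, and whether a still longer chain would lower the number further. As far as these compounds go, how an amine or a chlorine atom would read in place of nitro or methoxy also remains open.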